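Halogen swap at the 4-fluorophenyl group of compound 2

The source may report more compounds than this note shows. Statements on the series, on what has been measured and on what is new or still open speak of the compounds shown alone.

- compound 1 `COc1ccc(C(=O)/C=C/c2cc(Br)cc(Br)c2Oc2c([N+](=O)[O-])cc(C(F)(F)F)cc2[N+](=O)[O-])cc1`: 13.2 ug/mL
- compound 2 `O=C(/C=C/c1cc(Br)cc(Br)c1Oc1c([N+](=O)[O-])cc(C(F)(F)F)cc1[N+](=O)[O-])c1ccc(F)cc1`: 120 ug/mL
- compound 3 `O=C(/C=C/c1cccc(Br)c1Oc1c([N+](=O)[O-])cc(C(F)(F)F)cc1[N+](=O)[O-])c1ccc(F)cc1`: 26.3 ug/mL

In a functional assay on A549 cells (Homo sapiens) for antiproliferative activity, read by MTT assay, with a stated time of 48 h (a higher number here means a weaker inhibitor, a lower number a stronger inhibitor), compound 2 gives 120 ug/mL, the highest of the three numbers. Compound 4 `O=C(/C=C/c1cc(Br)cc(Br)c1Oc1c([N+](=O)[O-])cc(C(F)(F)F)cc1[N+](=O)[O-])c1ccc(Br)cc1` carries bromo in place of fluoro on an aromatic carbon, para to a large group. The nearest evidence is a 9.1-fold higher number from compound 1 to compound 2 (0.96 log units; beyond the scatter), a modest step that also exchanges the group at this place. A different change, hydrogen in place of bromo, gives a 4.6-fold lower number from compound 2 to compound 3 (0.66 log units; beyond the scatter), also modest. No direct exchange of fluoro for bromo has been measured, so the evidence is indirect. A modest step towards a lower number is expected, with wide uncertainty, and the estimate is a 2.7-fold lower number from compound 2 to compound 4 (0.43 log units; beyond the scatter). For compound 4 the estimated value is 45 ug/mL, with an expected range of 13 ug/mL to 130 ug/mL.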

Compound 4, half-maximal inhibitory concentration: 16.8 ug/mL
Estimate against measurement, compound 4: 2.7-fold (0.43 log units) above, within the range that was stated.
By their numbers in this assay, from the lowest: compounds 1, 4 and 3 (each within the scatter of the next); then compound 2.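

In this assay, the exchange of 4-fluorophenyl for 4-bromophenyl now has a direct reading at this place, with a 7.1-fold lower number from compound 2 to compound 4 (0.85 log units; beyond the scatter). Bromo and methoxy at this place read alike, with a 1.3-fold higher number from compound 1 to compound 4 (0.10 log units; within the scatter), so among the three groups shown here, only fluoro in compound 2 stands apart. Nothing measured here gives a cause for this.

Going by these compounds, compound 3 carries 4-fluorophenyl with one bromo fewer on the core, and whether the exchange reads the same on that core remains open. On these data alone, how chloro or an amine would read at this place also remains open.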